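Swapping the Aryl Thioether Substituent: Compound 3 Awaits Measurement

The compounds below may be only part of what the source reports. "The series", "measured", "known", "first", "only" and "open" are said of these compounds alone.

Measured compounds:
compound 1 `CC(O)(CSc1cc(C(F)(F)F)cc(C(F)(F)F)c1)C(=O)Nc1ccc(C#N)cc1C(F)(F)F`: 7760 nM
compound 2 `CC(O)(CSc1cccc(C(F)(F)F)c1)C(=O)Nc1cc(C(F)(F)F)cc(C(F)(F)F)c1`: 8750 nM

Both compounds were tested in a functional assay on LNCaP cells (Homo sapiens) for antiproliferative activity, read by fluorescence and propidium iodide staining, with a stated time of 96 h; a higher number here means a weaker inhibitor, a lower number a stronger inhibitor. Compound 2 returns the higher of the two numbers, but its gap to compound 1 lies within the scatter of repeated measurements, so the two cannot be ordered against each other. Compound 1 and compound 2 also differ in more than one place at once, so neither pair gives a clean single-change step to lean on.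

Compound 3 `CC(O)(CSc1ccccc1OC(F)(F)F)C(=O)Nc1cc(C(F)(F)F)cc(C(F)(F)F)c1` has not yet been measured. Relative to compound 2 the change is 2-(trifluoromethoxy)phenyl in place of 3-(trifluoromethyl)phenyl on a sulfur. The remainder of the molecule, including the amide and the tertiary alcohol, is unchanged.

For the measured compounds named here, with no single-change step available among the measured compounds, the expectation for this swap can only be modest. The step from compound 2 to compound 3 is expected to be about a 1.1-fold higher number from compound 2 to compound 3 (0.04 log units; within the scatter), which is no larger than the usual scatter. Compound 3 is therefore estimated at 9500 nM, with a range from 3500 nM to 26000 nM.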

Compound 3, half-maximal inhibitory concentration: 2910 nM
Beside the measured number, compound 3's estimate is 3.3-fold (0.51 log units) above it; the measured number lies below the stated range.
By their numbers in this assay, from the lowest: compound 3; then compounds 1 and 2 (each within the scatter of the next).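

In this assay, compound 1 and compound 2 could show nothing about any single group, as they differ in more than one place and their numbers lie within the scatter of each other. Compound 3 supplies the first clean reading: with the amide and the tertiary alcohol held constant, putting 2-(trifluoromethoxy)phenyl in place of 3-(trifluoromethyl)phenyl on a sulfur gives a 3.0-fold lower number from compound 2 to compound 3 (0.48 log units; beyond the scatter), so the aryl group at this position can shift the read-out by more than the scatter. No measurement at hand bears on what lies behind this shift.

The swap alters both the substituent and its place on the phenyl ring, and this single step cannot separate the two changes. On these data alone, whether an unsubstituted phenyl, or a methoxy group or a chlorine atom on that ring, would move the number in the same direction remains open, as does whether the step would hold with the other anilide of compound 1 on the amide.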